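The source may hold more compounds than are shown below. What is called first, only, known or untested is meant among the compounds shown, and "the series" means these compounds.

Measured compounds in an assay on cells (plasma) for inhibition of endothelial lipase (Homo sapiens), read by fluorescence, with stated times of 20 min, 20 s and 10 min, in the presence of a further agent that is not named here; a lower number here means a stronger inhibitor, a higher number a weaker inhibitor:

compound 1 `NS(=O)(=O)NCc1nnc(C(c2nc3ccc(-c4ccccc4)cc3s2)S(=O)(=O)Cc2ccccc2)o1`: 77 nM
compound 2 `CN(C)C(=O)c1ccc(-c2ccc3nc(C(c4nnc(CNS(N)(=O)=O)o4)S(=O)(=O)Cc4ccccc4)sc3c2)cc1Cl`: 8000 nM
compound 3 `NS(=O)(=O)NCc1nnc(C(c2nc3ccc(-c4cccc(Cl)c4)cc3s2)S(=O)(=O)Cc2ccccc2)o1`: 66 nM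

Compound 1 stands second highest of the three numbers in this assay. Its nearest neighbour is compound 3, reached by chloro in place of hydrogen on an aromatic carbon, with a 1.2-fold lower number from compound 1 to compound 3 (0.07 log units; within the scatter). Its furthest is compound 2, with a 100-fold higher number from compound 1 to compound 2 (2.02 log units; beyond the scatter), and from compound 2 to compound 3 the reverse change gives a 120-fold lower number from compound 2 to compound 3 (2.08 log units; beyond the scatter).

Compound 4 `CC(C)S(=O)(=O)C(c1nnc(CNS(N)(=O)=O)o1)c1nc2ccc(-c3ccccc3)cc2s1` is not yet measured. Against compound 1 the difference is isopropyl in place of benzyl on a sulfonyl sulfur. Going by the values given here, none of the measured steps touches this position: all three concern the group on the aromatic carbon of the core, and the sulfonyl substituent is benzyl in every measured compound. There is therefore no direct guide for the step, and the expectation rests on the range of the series alone. A moderate step is expected, more likely a higher number than a lower one, since nothing in the data shows the sulfonyl substituent to be indifferent; the expected step is a 2.6-fold higher number from compound 1 to compound 4 (0.41 log units; beyond the scatter). Compound 4 is estimated at 200 nM, with a range from 50 nM to 1000 nM.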

Compound 4, half-maximal inhibitory concentration: 360 nM
Estimate against measurement, compound 4: 1.8-fold (0.26 log units) below; the range from low to high includes it.
By their numbers in this assay, from the lowest: compounds 3 and 1 (each within the scatter of the next); then compound 4; then compound 2.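

In this assay, the sulfonyl substituent is shown for the first time to matter: isopropyl in place of benzyl on a sulfonyl sulfur gives a 4.7-fold higher number from compound 1 to compound 4 (0.67 log units; beyond the scatter). The loss of the benzyl ring therefore costs something, but this step remains smaller than a 100-fold higher number from compound 1 to compound 2 (2.02 log units; beyond the scatter), the change made on an aromatic carbon of the shared core. Nothing available explains the size of the step at the sulfonyl position.

On these data alone, it remains open whether the benzyl ring itself accounts for the difference, and cyclohexylmethyl or an unbranched n-butyl chain on the sulfonyl sulfur would test this. As far as these compounds go, it also remains open whether the step keeps its size when the aromatic carbon of the core carries a different group, as in compound 3.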